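A few compounds are considered here, and "the series" means these few. Any claim that something is new, unique, unknown or untested is made for them only; others in the source may bear on it.

Compound 1 `CCCN(CCC)c1nc(C(F)(F)F)ccc1CNC(=O)C(C)c1ccc(NS(C)(=O)=O)c(F)c1`: 0.2 nM
Compound 2 `CC(C(=O)NCc1ccc(C(F)(F)F)nc1N1CCC(Cc2ccc(F)c(F)c2)CC1)c1ccc(NS(C)(=O)=O)c(F)c1`: 0.2 nM
Compound 3 `CC(C(=O)NCc1ccc(C(F)(F)F)nc1N1CCC(C(=O)c2ccc(F)cc2)CC1)c1ccc(NS(C)(=O)=O)c(F)c1`: 3.9 nM

The three compounds share a core and were tested in a functional assay on CHO-K1 cells for antagonist activity at transient receptor potential cation channel subfamily V member 1 (Homo sapiens), read by FLIPR; a lower number here means a stronger inhibitor, a higher number a weaker inhibitor. Compound 1 gives 0.2 nM and compound 2 gives 0.2 nM, two values that lie within the scatter of each other. Compound 3, with 3.9 nM, stands at the highest of the three numbers, and its gap to compound 1 and to compound 2 lies beyond the scatter in both cases. Among the measured compounds shown here, the only measured step that changes one place, a 20-fold higher number from compound 2 to compound 3 (1.29 log units; beyond the scatter), is a large one, and it concerns the group on the saturated ring carbon.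

Compound 4 `CC(C(=O)NCc1ccc(C(F)(F)F)nc1N1CCC(O)CC1)c1ccc(NS(C)(=O)=O)c(F)c1` has not yet been measured. It differs from compound 3 at that same saturated ring carbon: hydroxy in place of (4-fluorophenyl)carbonyl on a saturated ring carbon. For the measured compounds named here, the step from compound 2 to compound 3 shows that exchanging the group there can move the number strongly, but no measured compound carries a hydroxy at this place, so the direction of the new step is not settled by the data. On this basis compound 4 is expected to give a step of a 3.8-fold higher number from compound 3 to compound 4 (0.59 log units; beyond the scatter) towards a higher number, with wide uncertainty. Compound 4 is estimated at 15 nM, within a range from 3 nM to 80 nM.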

Compound 4, inhibition constant: "not active" (no number reported)
The entry for compound 4 holds no number, so the estimate cannot be set against anything.
By their numbers in this assay, from the lowest: compounds 1 and 2 (each within the scatter of the next); then compound 3.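

In this assay, among the compounds shown here, compound 4 is reported as "not active" with no number, so no step from compound 3 to compound 4 can be read. Nothing shown here bears on this result. The compounds shown leave open how a hydroxy on that saturated ring carbon compares numerically with the groups carried by compound 2 and compound 3.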